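The source may hold more compounds than are shown below. What is called first, only, known or untested is meant among the compounds shown, and "the series" means these compounds.

Compound 2 `C/C(=N\OC(c1ccc(OCc2nc(-c3ccccc3)cs2)cc1)C1CCCCC1)C(=O)O` gives 20 nM in a functional assay for inhibition of Polyunsaturated fatty acid 5-lipoxygenase (Homo sapiens) (a lower number here means a stronger inhibitor, a higher number a weaker inhibitor), the lowest of the two numbers in hand, with compound 1 `O=C(O)/C=N/OC(c1ccc(OCc2nc(-c3ccccc3)cs2)cc1)C1CCCCC1` nearest at 21 nM, a gap that lies within the scatter. Among the measured compounds shown here, the only measured step, a 1.1-fold lower number from compound 1 to compound 2 (0.02 log units; within the scatter), sits on an oxygen on a saturated carbon and leaves the 4-phenyl-1,3-thiazol-2-yl group untouched. Compound 3 `C/C(=N\OC(c1ccc(OCc2nc3ccccc3n2C)cc1)C1CCCCC1)C(=O)O` differs from compound 2 in 1-methyl-1H-benzimidazol-2-yl in place of 4-phenyl-1,3-thiazol-2-yl on a saturated chain carbon bound to an oxygen on an aromatic ring. For the measured compounds named here, no measured step covers a change at this place, so neither the direction nor the size of its effect in this assay can be read from the numbers in hand, and the one measured step, being within the scatter, says nothing about it. Compound 3 is therefore estimated at 60 nM in this assay, a step of a 3.0-fold higher number from compound 2 to compound 3 (0.48 log units; beyond the scatter) that is expected to fall anywhere between 15 nM and 300 nM.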

Compound 3, half-maximal inhibitory concentration: 820 nM
Beside the measured number, compound 3's estimate is 14-fold (1.14 log units) below it, outside the stated range (above it).
By their numbers in this assay, from the lowest: compounds 2 and 1 (each within the scatter of the next); then compound 3.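

In this assay, the group on a saturated chain carbon bound to an oxygen on an aromatic ring proves to matter: 1-methyl-1H-benzimidazol-2-yl in place of 4-phenyl-1,3-thiazol-2-yl brings a 41-fold higher number from compound 2 to compound 3 (1.61 log units; beyond the scatter), whereas the earlier step, on an oxygen on a saturated carbon, stayed within the scatter. The two groups have the same ring types and the same counts of donors and acceptors, so these counts do not separate them in this pair. Nothing measured on either group bears on this result.

The compounds shown leave open which part of the exchange carries the step, the phenyl on the thiazole or the methyl and fused ring of the benzimidazole. A plain 1,3-thiazol-2-yl or a 1H-benzimidazol-2-yl group without the methyl would speak to this at the same place.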